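The source may hold more compounds than are shown below. What is called first, only, known or untested is meant among the compounds shown, and "the series" means these compounds.

Among the compounds with values here, compound 1 `CCCCCCCCCCCCCCCCCCNC(=O)[C@@H]1CSC(c2cccc(O)c2)N1` is the one member of the set with a number in a functional assay on PC-3 cells (Homo sapiens) for antiproliferative activity, read by sulforhodamine B assay (on this read-out lower numbers stand for stronger inhibition and higher numbers for weaker inhibition), where compound 1 gives 6700 nM. Compound 2 `CCCCCCCCN(CCCCCCCC)C(=O)[C@@H]1CSC(c2cc(OC)c(OC)c(OC)c2)N1` reaches only the limit of this assay, > 20000 nM. Compound 3 `CCCCCCCCCCCCCCCCCCNC(=O)[C@H]1NC(c2cc(OC)c(OC)c(OC)c2)SC1(C)C` likewise stands at the limit of this assay, > 20000 nM; the set thus rests on (the limit of > 20000 nM in this assay, at which 2 of the 3 values shown sit). Compound 4 `CCCCCCCCCCCCCCCCCCNC(=O)[C@H]1NC(c2ccc(N(C)C)cc2)SC1(C)C` carries 4-(dimethylamino)phenyl in place of 3,4,5-trimethoxyphenyl on a saturated ring carbon. Within the data shown here, no measured pair differs in a single place, so no step in this assay for such a change is known; the change is expected to shift potency in this assay by little beyond the scatter, with a fair chance of another limit. Compound 4 is estimated at 15000 nM, within 4000 nM to 40000 nM. The implied step is expected to be an at least 1.3-fold lower number from compound 3 to compound 4 (0.12 log units; that floor lies within the scatter).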

Compound 4, half-maximal inhibitory concentration: > 20000 nM
Compound 4: only a limit was reported; the forecaster's own chance of this, stated with the estimate: 40%; middle value at least 1.3-fold (0.12 log units) away from the limit.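

In this assay, within the data shown here, compound 3 and compound 4 both sit at a limit, so no step between them can be read. Whether 4-(dimethylamino)phenyl in place of 3,4,5-trimethoxyphenyl changes potency at all stays open, with the set resting largely on one limit: the limit of > 20000 nM in this assay, at which 3 of the 4 values shown sit.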